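Swapping the trimethoxyphenyl for benzyl on the shared core

The source may hold more compounds than are shown below. What is called first, only, known or untested is meant among the compounds shown, and "the series" means these compounds.

Measured compounds:
compound 1 `Cc1ccc(S(=O)(=O)/N=C(/CCNC2=CC(=O)c3ccccc3C2=O)Nc2ccc(F)c(F)c2)cc1` — 9420 nM
compound 2 `Cc1ccc(S(=O)(=O)/N=C(/CCNC2=CC(=O)c3ccccc3C2=O)Nc2ccc(Cl)cc2Cl)cc1` — 17000 nM
compound 3 `COc1cc(N/C(CCNC2=CC(=O)c3ccccc3C2=O)=N\S(=O)(=O)c2ccc(C)cc2)cc(OC)c1OC` — 3050 nM

In a functional assay on MCF7 cells (Homo sapiens) for cytotoxicity, read by MTT assay, with a stated time of 48 h (on this read-out higher numbers stand for weaker inhibition and lower numbers for stronger inhibition), compound 3 gives the lowest of the three numbers, and its steps to the other two lie beyond the scatter: a 3.1-fold lower number from compound 1 to compound 3 (0.49 log units; beyond the scatter) and a 5.6-fold lower number from compound 2 to compound 3 (0.75 log units; beyond the scatter). Between the two halogenated compounds the difference is small, as a 1.8-fold higher number from compound 1 to compound 2 (0.26 log units; within the scatter) shows. Compound 4 `Cc1ccc(S(=O)(=O)/N=C(/CCNC2=CC(=O)c3ccccc3C2=O)NCc2ccccc2)cc1` is not yet measured. It differs from compound 3 in one place: benzyl in place of 3,4,5-trimethoxyphenyl on an amine nitrogen.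

Among the measured compounds shown here, no measured step bears directly on this change. What the three measured steps do show is that the trimethoxyphenyl group went with the lowest number, while the two halogenated phenyl groups went with higher ones. Benzyl is a third kind of group, closer in size to the halogenated phenyls than to the trimethoxyphenyl, and carrying no hydrogen-bond acceptors. The step from compound 3 to compound 4 is therefore expected to run upward, by roughly a 3.0-fold higher number from compound 3 to compound 4 (0.47 log units; beyond the scatter), with wide uncertainty. For compound 4 in this assay the estimate is 9000 nM, within a range from 3000 nM to 30000 nM.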

Compound 4, half-maximal inhibitory concentration: 3630 nM
Compound 4: the middle estimate sits 2.5-fold (0.39 log units) above what was measured, within the range that was stated.
By their numbers in this assay, from the lowest: compounds 3 and 4 (each within the scatter of the next); then compounds 1 and 2 (each within the scatter of the next).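

In this assay there is a 1.2-fold higher number from compound 3 to compound 4 (0.08 log units; within the scatter) and so, on this amine nitrogen, benzyl cannot be told apart from 3,4,5-trimethoxyphenyl, although benzyl has fewer heavy atoms and no hydrogen-bond acceptors. Benzyl does differ from both halogenated phenyl groups, with a 4.7-fold lower number from compound 2 to compound 4 (0.67 log units; beyond the scatter) and a 2.6-fold lower number from compound 1 to compound 4 (0.41 log units; beyond the scatter) in the same direction, so the lower numbers no longer belong to the trimethoxyphenyl group alone, and its oxygen atoms are not required for them among these compounds. No supporting data explain why two such different groups give matching results.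

The compounds shown leave open whether the result for compound 4 depends on the carbon link that benzyl places on the nitrogen or simply on a ring without halogens. A plain phenyl group, a phenethyl group with its longer chain, or a chlorobenzyl group on the same nitrogen would help to separate these two possibilities.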